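The source may report more compounds than this note shows. Statements on the series, on what has been measured and on what is new or still open speak of the compounds shown alone.

Measured so far in an assay on CHO cells for displacement of a labelled ligand from melatonin receptor type 1A (Homo sapiens), with a stated time of 120 min; on this read-out lower numbers stand for stronger inhibition and higher numbers for weaker inhibition:
- compound 1, `CCC(=O)NCC1CCc2ccccc2N1CC(=O)NC`, gives > 10000 nM; this value is a limit of the assay, not a number.
- compound 2, `CCNC(=O)NCC1CCc2ccccc2N1`, gives 115 nM.

Within the data shown here, compound 2 stands as the only numbered value in this assay; the one other value shown is a limit. The step to compound 3, `CCC(=O)NCC1CCc2ccccc2N1`, is ethyl in place of ethylamino on a carbonyl carbon. No measured step of this kind is available, so the expected change is a modest one, at most a little beyond the usual scatter, towards stronger inhibition, shown as a 2.3-fold lower number from compound 2 to compound 3 (0.36 log units; beyond the scatter). For compound 3 the estimated value in this assay is 50 nM, expected to fall between 10 nM and 300 nM.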

Compound 3, inhibition constant: 13 nM
Compound 3: middle estimate off by 3.8-fold (0.59 log units), on the high side, and the stated range covers the measured number.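

In this assay, ethyl in place of ethylamino on a carbonyl carbon gives an 8.8-fold lower number from compound 2 to compound 3 (0.95 log units; beyond the scatter), so the hydrogen-bond donor of the ethylamino group is not required for binding at this position. Hydrogen in place of (methylcarbamoyl)methyl on a nitrogen on an aromatic ring gives an at least 760-fold lower number from compound 1 to compound 3 (2.88 log units; beyond the scatter), which shows that this nitrogen is sensitive to substitution. Compound 1 stands at a limit, so the true size of that step stays unknown: the limit of > 10000 nM in this assay, at which 1 of the 3 values shown sits.

Open, as far as these compounds go, is whether a longer chain such as butanoyl on the carbonyl carbon keeps the gain. Also open, from the compounds shown here alone, is whether a methyl group on that nitrogen is accepted, or whether any substituent there costs as much as (methylcarbamoyl)methyl.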